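Swapping the Pyrrole in an Alpha-1B Agonist Series

The source may report more compounds than this note shows. Statements on the series, on what has been measured and on what is new or still open speak of the compounds shown alone.

Measured so far:
- compound 1, `c1ccc(-c2cnccn2)c(OCC2=NCCN2)c1`: 631 nM
- compound 2, `c1c[nH]c(-c2ccccc2OCC2=NCCN2)c1`: 1 nM

Both compounds were tested in a functional assay for activation of Alpha-1B adrenergic receptor (Homo sapiens), read by calcium flux; on this read-out higher numbers stand for an effect only at larger amounts of compound and lower numbers for an effect already at smaller amounts. Going by the values given here, compound 2 stands at the lower of the two numbers, and the only step so far leads to it: a 630-fold lower number from compound 1 to compound 2 (2.80 log units; beyond the scatter), a large change that came from putting 1H-pyrrol-2-yl in place of pyrazin-2-yl on an aromatic carbon.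

Compound 3, `Cc1cnsc1-c1ccccc1OCC1=NCCN1`, is not yet measured. It differs from compound 2 in one place: 4-methyl-1,2-thiazol-5-yl in place of 1H-pyrrol-2-yl on an aromatic carbon. The group that leaves carries one hydrogen-bond donor and no acceptor, the group that enters carries no donor and two acceptors, much as pyrazin-2-yl in compound 1 carries acceptors and no donor. Among the compounds with values here, the one measured step therefore bears directly on this change: the loss of the pyrrole and the gain of an acceptor-bearing ring in compound 1 went with a 630-fold lower number from compound 1 to compound 2 (2.80 log units; beyond the scatter) read in reverse. Within the data shown here, a step upward in this assay is thus expected for compound 3, though the entering ring also brings a methyl group and a sulfur, for which no measured step exists, so the size is uncertain. The expected step is a 50-fold higher number from compound 2 to compound 3 (1.70 log units; beyond the scatter). For compound 3 the estimate is 50 nM, in the range 5 nM to 500 nM.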

Compound 3, half-maximal effective concentration: < 100000 nM
Compound 3 gave a limit, no number; the forecaster's own chance of this, stated with the estimate: 5%; the middle value lies beyond the limit too.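

In this assay compound 3 gives < 100000 nM, which is a limit of the assay and not a number. Going by these compounds alone, no step from compound 1 or compound 2 to compound 3 can be read from it. Still open, on these data alone, is where the true number of compound 3 lies, and so how 4-methyl-1,2-thiazol-5-yl compares with 1H-pyrrol-2-yl or pyrazin-2-yl.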